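Swapping one group on compound 1: what happens to cell toxicity?

The compounds below may be only part of what the source reports. "The series", "measured", "known", "first", "only" and "open" are said of these compounds alone.

Of the compounds shown here, three that share a core have been measured in an ADME assay on L6 cells (Rattus norvegicus) for cytotoxicity; on this read-out higher numbers stand for weaker inhibition and lower numbers for stronger inhibition. Here compound 1 (`O=C(Nc1c(O)cccc1-c1nc2c(C(=O)O)cccc2o1)c1ccc(F)c(F)c1F`) gives 210000 nM, compound 2 (`O=C(Nc1ccccc1-c1nc2c(C(=O)O)cccc2o1)c1ccccc1`) gives 114000 nM and compound 3 (`COc1cccc(-c2nc3c(C(=O)O)cccc3o2)c1NC(=O)c1cc2ccccc2[nH]1`) gives 211000 nM. Compound 1 lies within the usual scatter of repeated measurements of both others, so these numbers set no order among the three.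

The next compound to test is compound 4 (`O=C(Nc1c(O)cccc1-c1nc2c(C(=O)O)cccc2o1)c1cc(-c2ccccc2)on1`), which comes from compound 1 by a single change: 5-phenyl-1,2-oxazol-3-yl in place of 2,3,4-trifluorophenyl on a carbonyl carbon. In words, 5-phenyl-1,2-oxazol-3-yl takes the place of 2,3,4-trifluorophenyl on a carbonyl carbon whose other neighbour is an amide-type nitrogen.

Among the compounds with values here, no two measured compounds differ in one place only, so no measured step speaks directly to this swap. The best guide is indirect. The three measured compounds carry different groups on that carbonyl carbon, and they also differ elsewhere, yet compound 2 at 114000 nM and compound 3 at 211000 nM stay within the scatter of each other. No change beyond the scatter is therefore expected in this assay, and the estimated step is a 1.2-fold lower number from compound 1 to compound 4 (0.09 log units; within the scatter). For compound 4 the estimated value is 170000 nM, with an expected range from 70000 nM to 300000 nM.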

Compound 4, half-maximal inhibitory concentration: 141000 nM
Beside the measured number, compound 4's estimate is 1.2-fold (0.08 log units) above it, and the stated range covers the measured number.
By their numbers in this assay, from the lowest: compounds 2, 4, 1 and 3 (each within the scatter of the next).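

Within the data shown here, this is the first pair that differs in one place only, so the group on the carbonyl carbon can now be judged on its own: in this assay the swap gives a 1.5-fold lower number from compound 1 to compound 4 (0.17 log units; within the scatter), which does not count as a real change. The exchange is not a small one by the counts, since 2,3,4-trifluorophenyl has one aromatic ring and no hydrogen-bond acceptors, while 5-phenyl-1,2-oxazol-3-yl has two aromatic rings and two hydrogen-bond acceptors, yet the read-out stays within the scatter. Nothing available explains this result, so it stands as an observation only.

A single step with two groups cannot show whether this position accepts most changes or whether these two simply happen to match. Going by these compounds, it remains open whether a different kind of group on that carbonyl carbon, such as an amine, a carboxylic acid or a longer alkyl chain, would move the number beyond the scatter.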